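Chloro-to-hydrogen step on the pyrimidine-side aryl

The source may hold more compounds than are shown below. What is called first, only, known or untested is meant among the compounds shown, and "the series" means these compounds.

Two compounds of the series have been run in a functional assay on U-87MG ATCC cells for antiproliferative activity against U-87 MG (Homo sapiens), read by MTT assay, with a stated time of 48 h, tested at 10 uM; a lower number here means a stronger effect, a higher number a weaker effect of the compound at the concentration tested. Compound 1 `COc1ccc(-c2nc(C)c(C(=O)CSc3nc(N)c(C#N)c(-c4ccccc4)n3)s2)cc1` gives 57.8% in this assay. Compound 2 `Cc1nc(-c2ccc(Cl)cc2)sc1C(=O)CSc1nc(N)c(C#N)c(-c2ccc(Cl)cc2)n1` gives 37.3% in this assay, the lowest of the two numbers, and its nearest neighbour is compound 1, whose number lies higher by a margin beyond the scatter. Within the data shown here, the two compounds differ in more than one place, so no single step between them can be read off; only their two values can be set side by side.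

Compound 3 `Cc1nc(-c2ccc(Cl)cc2)sc1C(=O)CSc1nc(N)c(C#N)c(-c2ccccc2)n1` has not yet been measured in this assay. Its difference from compound 2 is hydrogen in place of chloro on an aromatic carbon. The aryl group on the core of compound 2 that keeps its chloro is untouched.

Among the measured compounds shown here, no measured pair isolates this change, so the expected size of the step rests only on the two values at hand. A step from compound 2 to compound 3 of a number 9.7 percentage points higher from compound 2 to compound 3 (within the scatter) is expected, a modest rise that may well stay within the scatter. Compound 3 is therefore estimated at 47% in this assay, with a range from 30% to 65%.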

Compound 3, a percentage reported as activity, at one concentration (the size of the read-out at that concentration, not a potency): 67.9%
For compound 3 the middle estimate is 20.9 percentage points below the measured one, and the stated range ends below it.
By their numbers in this assay, from the lowest: compound 2; then compound 1; then compound 3.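

Compound 1 and compound 2 differ in more than one place and could not provide a single-place reading at this position. In this assay, the change from 4-chlorophenyl to phenyl gives the first such reading: a number 30.6 percentage points higher from compound 2 to compound 3 (beyond the scatter), a large step toward a weaker effect at the concentration tested. The other aryl group now has a single-place reading too, with chloro in place of methoxy giving a number 10.1 percentage points higher from compound 1 to compound 3 (beyond the scatter), a modest step in the same direction on a core that carries phenyl at the first position. Nothing available bears on why the number moves at either place.

It remains open whether the chloro step keeps its size when the other aryl group carries methoxy rather than chloro, since only one such pair is shown. The reading at this position also covers only chloro and hydrogen, so a methoxy group, an amine or a carboxylic acid on the same aromatic carbon could fall on either side of these two values.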